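This account rests on a few compounds, and the source may have more. Where it says the series, first, only, none or still open, it means among the compounds named here.

- Compound 1 `O=C1c2c[n+]([O-])c3ccccc3c2C(=O)c2c1c1ccccc1n2CCN1CCCC1` gives 630 nM
- Compound 2 `O=C1c2c[n+]([O-])c3ccccc3c2C(=O)c2c1c1ccccc1n2CCCCN1CCNCC1` gives 3310 nM
- Compound 3 `CCCCN1CCN(CCCCn2c3c(c4ccccc42)C(=O)c2c[n+]([O-])c4ccccc4c2C3=O)CC1` gives 900 nM

In a functional assay on MDA-MB-231 cells (Homo sapiens) for cytotoxicity, read by MTT assay, with a stated time of 72 h (a lower number here means a stronger inhibitor, a higher number a weaker inhibitor), compound 3 gives 900 nM and is the second highest of the three numbers. It sits close to one neighbour and well apart from the other: a 1.4-fold higher number from compound 1 to compound 3 (0.15 log units; within the scatter) stands against a 3.7-fold lower number from compound 2 to compound 3 (0.57 log units; beyond the scatter) in this series.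

The next structure is compound 4 `O=C1c2c[n+]([O-])c3ccccc3c2C(=O)c2c1c1ccccc1n2CCCCN1CCCCC1` and the change is piperidin-1-yl in place of 4-butylpiperazin-1-yl on a saturated chain carbon, four bonds along the chain from an aromatic nitrogen at the far end of the chain. In words, this puts piperidin-1-yl in place of 4-butylpiperazin-1-yl on a saturated chain carbon, four bonds along the chain from an aromatic nitrogen.

Among the compounds with values here, no measured step makes exactly this swap, so the evidence is indirect. Exchanging the end ring gave only a 1.4-fold higher number from compound 1 to compound 3 (0.15 log units; within the scatter) as a shift. Compound 2 is the one that stands apart, with a hydrogen on its ring amine nitrogen, through the modest 5.3-fold higher number from compound 1 to compound 2 (0.72 log units; beyond the scatter) and the reverse 3.7-fold lower number from compound 2 to compound 3 (0.57 log units; beyond the scatter) when butyl replaces that hydrogen. Compound 4 has no such hydrogen, so it is expected to resemble compound 1 and compound 3 rather than compound 2.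

The expected change is small, namely a 1.1-fold lower number from compound 3 to compound 4 (0.05 log units; within the scatter) as an estimate. For compound 4 the estimated value is 800 nM with an expected range from 300 nM to 2200 nM in this assay.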

Compound 4, half-maximal inhibitory concentration: 610 nM
Compound 4: the middle estimate sits 1.3-fold (0.12 log units) above what was measured, and the stated range covers the measured number.
By their numbers in this assay, from the lowest: compounds 4, 1 and 3 (each within the scatter of the next); then compound 2.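

At this place, on a saturated chain carbon, four bonds along the chain from an aromatic nitrogen, 4-butylpiperazin-1-yl can give way to the smaller piperidin-1-yl, which has one ring nitrogen and no butyl group, with only a 1.5-fold lower number from compound 3 to compound 4 (0.17 log units; within the scatter) in this assay. Exchanging piperazin-1-yl, with its hydrogen on the ring amine nitrogen, for piperidin-1-yl at the same place gives a 5.4-fold lower number from compound 2 to compound 4 (0.73 log units; beyond the scatter) and so, among these four compounds, only compound 2, the one carrying that hydrogen, stands apart, with none going against this. The step of a 1.0-fold lower number from compound 1 to compound 4 (0.01 log units; within the scatter) adds that piperidin-1-yl at this place matches pyrrolidin-1-yl two bonds along the chain, though ring and chain differ together in that pair, so their separate contributions cannot be told apart.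

No supporting evidence is available to explain these results. Still open, on these data alone, is whether a morpholin-4-yl ring or a simple dimethylamino group at this place would match compound 4 or compound 2, and whether pyrrolidin-1-yl four bonds along the chain would match compound 1.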